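The compounds below may be only part of what the source reports. "The series", "measured", "known", "first", "only" and "open" are said of these compounds alone.

Of the compounds shown here, three built on a shared core have been measured in a functional assay on K562 cells (Homo sapiens) for inhibition, read by sulforhodamine B assay, with a stated time of 48 h; a lower number here means a stronger inhibitor of growth, a higher number a weaker inhibitor of growth. Compound 1 `N#C/C(=C\N1CCN(C(=O)c2ccco2)C1=S)C(N)=O` gives 9100 nM. Compound 2 `O=CN1CCN(C(=O)c2ccco2)C1=S` gives 2600 nM, a lower number that lies beyond the scatter of compound 1. Compound 3 `O=CN1CCN(c2cc(Cl)cc(Cl)c2)C1=S` gives 14800 nM, which sits within the scatter of compound 1. Compound 1 therefore stands between the other two, set apart clearly only from compound 2. Compound 4 `N#C/C(=C\N1CCN(C(=O)c2ccco2)C1=S)C(=O)c1ccccc1` has not yet been measured. It differs from compound 1 in one place: phenyl in place of amino on a carbonyl carbon. For the measured compounds named here, no measured pair shows what this change does, so the expected step of a 1.5-fold lower number from compound 1 to compound 4 (0.18 log units; within the scatter) is judged small, of uncertain direction and not clearly beyond the scatter. On that basis compound 4 is estimated at about 6000 nM, with a range from 1500 nM to 25000 nM.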

Compound 4, concentration for 50% growth inhibition: 5500 nM
For compound 4 the middle estimate is 1.1-fold (0.04 log units) above the measured one; measured number inside the range.
By their numbers in this assay, from the lowest: compound 2; then compounds 4, 1 and 3 (each within the scatter of the next, the first and the last beyond it).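

In this assay, for the compounds shown here, the change from carbamoyl to benzoyl gives a 1.7-fold lower number from compound 1 to compound 4 (0.22 log units; within the scatter) and provides the first reading at this position. On a carbonyl carbon, then, a phenyl ring can replace amino, and the hydrogen-bond donor of amino can be lost, with no change in growth inhibition that stands clear of the scatter. No supporting evidence explains this result.

Still open, from the compounds shown here alone, is whether a methyl group, a carboxylic acid or a longer alkyl chain on this carbonyl carbon would move the number beyond the scatter. Substituted phenyl rings, such as chlorophenyl, pose the same question.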